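Replacing the benzylamine linker with an aryl sulfur linker

This account rests on a few compounds, and the source may have more. Where it says the series, first, only, none or still open, it means among the compounds named here.

Compound 3 `Nc1cc(N)c2nc(-c3ccccc3)c(NCc3ccc(F)cc3)nc2c1` gives 2140 nM in a functional assay on SNB-75 cells (Homo sapiens) for inhibition, read by sulforhodamine B assay, with a stated time of 48 h (on this read-out lower numbers stand for stronger inhibition of growth and higher numbers for weaker inhibition of growth), the lowest of the two numbers shown. Compound 2 `COc1ccc(CNc2nc3cc(N)cc(N)c3nc2-c2ccccc2)cc1OC` gives 16200 nM, and a 7.6-fold lower number from compound 2 to compound 3 (0.88 log units; beyond the scatter). Compound 1 `CCOC(=O)[C@H](CCC(=O)O)NC(=O)c1ccc(CNc2nc3cc(N)cc(N)c3nc2-c2ccccc2)cc1` reaches only a limit, < 100000 nM; (the limit of < 100000 nM in this assay, at which 1 of the 3 values shown sits). Compound 4 `Nc1cc(N)c2nc(-c3ccccc3)c(Sc3ccc(F)cc3)nc2c1` differs from compound 3 by (4-fluorophenyl)sulfanyl in place of (4-fluorobenzyl)amino on an aromatic carbon. Among the measured compounds shown here, the one measured step changed the substituents on the benzyl ring while keeping the linker, so it does not bear on this change, and no evidence on the measured steps speaks to it. Without a guide, no direction is expected with confidence, and the expected step is a 2.1-fold higher number from compound 3 to compound 4 (0.32 log units; beyond the scatter). Compound 4 is estimated at 4500 nM, with a range from 1000 nM to 20000 nM.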

Compound 4, concentration for 50% growth inhibition: 20900 nM
Beside the measured number, compound 4's estimate is 4.6-fold (0.67 log units) below it, outside the stated range (above it).
By their numbers in this assay, from the lowest: compound 3; then compounds 2 and 4 (each within the scatter of the next).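

In this assay, the change gives a 9.8-fold higher number from compound 3 to compound 4 (0.99 log units; beyond the scatter), so growth inhibition weakens when the linking atoms change even though the 4-fluorophenyl ring stays. Among the compounds shown here, the earlier step altered only that ring's substituents, whereas this one shows that the link to the core matters too. The swap removes the nitrogen, its hydrogen-bond donor and the saturated chain carbon together, and nothing shown explains the loss. Still open, from the compounds shown here alone, is which of these changes counts most. A (4-fluorophenyl)amino group, keeping the nitrogen without the chain carbon, would help separate them.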